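Phenyl for Cyclopropyl on a Carbonyl, Made Twice

The source may hold more compounds than are shown below. What is called first, only, known or untested is meant among the compounds shown, and "the series" means these compounds.

Measured in a functional assay on HCT-116 cells (Homo sapiens) for cytotoxicity, read by sulforhodamine B assay, with a stated time of 48 h; on this read-out higher numbers stand for weaker inhibition and lower numbers for stronger inhibition:
Compound 1, `CCCCNC(=O)N1Cc2c(NC(=O)c3ccc(C)cc3)nn(C(=O)C3CC3)c2C1`, gives 17600 nM.
Compound 2, `CCCCNC(=O)N1Cc2c(NC(=O)c3ccc(C)cc3)nn(C(=O)c3ccccc3)c2C1`, gives 23200 nM.
Compound 3, `O=C(Nc1nn(C(=O)C2CC2)c2c1CN(C(=O)c1ccccc1)C2)c1ccc(F)cc1`, gives 2280 nM.

Compound 1 and compound 2 share a core and differ in one place: phenyl in place of cyclopropyl on a carbonyl carbon. That change gave a 1.3-fold higher number from compound 1 to compound 2 (0.12 log units; within the scatter). Compound 3 carries a different core; the difference between the two cores is not broken down here. Its value is the lowest of the three, and its gaps to compound 1 and to compound 2 both lie beyond the scatter.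

Compound 4, `O=C(Nc1nn(C(=O)c2ccccc2)c2c1CN(C(=O)c1ccccc1)C2)c1ccc(F)cc1`, has not yet been measured. It differs from compound 3 by phenyl in place of cyclopropyl on a carbonyl carbon, the same change as from compound 1 to compound 2, at a place described in the same words.

Compound 4 is expected to sit a 1.3-fold higher number from compound 3 to compound 4 (0.12 log units; within the scatter). This rests on the earlier step, a 1.3-fold higher number from compound 1 to compound 2 (0.12 log units; within the scatter), which stayed within the scatter, and on the value of compound 3 as the starting point. The estimate for compound 4 in this assay is therefore 3000 nM, with a range from 1200 nM to 7500 nM.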

Compound 4, half-maximal inhibitory concentration: 2780 nM
The estimate for compound 4 lay 1.1-fold (0.03 log units) above the measured number; the measured number falls inside the stated range.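

In this assay, putting phenyl in place of cyclopropyl on a carbonyl carbon gave a 1.2-fold higher number from compound 3 to compound 4 (0.09 log units; within the scatter), and the change behaved alike on the two cores: the same change on two cores in this assay, a 1.3-fold higher number (0.12 log units; within the scatter) from compound 1 to compound 2 and a 1.2-fold higher number (0.09 log units; within the scatter) from compound 3 to compound 4, 1.1-fold (0.03 log units) apart, within the scatter of two such steps. In these two pairs, then, the change carried from one core to the other, and on neither core did it move the number beyond the scatter. This does not show that cyclopropyl and phenyl are interchangeable across the series: it rests on two pairs alone. Both steps are small. Within the data shown here, the agreement shows only that the change did little on these two cores, not how it would behave on a third or why it did so little.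

The compounds shown leave open whether the carbonyl carbon tolerates groups other than these two rings, such as a longer chain like butyl, or a phenyl bearing an amine or a carboxylic acid. They also leave open whether the same small step would appear in cell lines other than this one.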